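The source may hold more compounds than are shown below. What is called first, only, known or untested is meant among the compounds shown, and "the series" means these compounds.

Measured so far in an ADME assay on the whole organism (Rattus norvegicus, strain Sprague-Dawley) for pharmacokinetics, using cassette dosing, at a dose of 1 mg/kg by the oral route; on this read-out lower numbers stand for lower oral bioavailability and higher numbers for higher oral bioavailability:
- Compound 1 `O=C(Nc1ccc2[nH]c(=O)oc2c1)C(=O)N1CCN(c2ccc(Cl)cc2)CC1`: 17.8%
- Compound 2 `O=C(Nc1ccc2[nH]c(=O)oc2c1)C(=O)N1CCN(c2ccc(F)c(F)c2)CC1`: 13%
- Compound 3 `C[C@@H]1CN(C(=O)C(=O)Nc2ccc3[nH]c(=O)oc3c2)CCN1c1ccc(Cl)cc1`: 52.6%

Compound 3 holds the highest of these three numbers in this assay, and compound 1 and compound 2 both lie well short of it. The next compound, compound 4 `C[C@@H]1CN(C(=O)C(=O)Nc2ccc3[nH]c(=O)oc3c2)CCN1c1ccc(F)c(F)c1`, keeps the methyl group of compound 3 and differs from it in one place: 3,4-difluorophenyl in place of 4-chlorophenyl on an amine nitrogen in a ring. Here 3,4-difluorophenyl stands in place of 4-chlorophenyl on an amine nitrogen in a ring, next to the ring atom that bears a methyl group.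

Among the measured compounds shown here, two measured steps bear on this change. The same exchange, made without the methyl group, shows a number 4.8 percentage points lower from compound 1 to compound 2 (within the scatter), a small step. The methyl group itself shows a number 34.8 percentage points higher from compound 1 to compound 3 (beyond the scatter), a large one, so compound 3 sits far from the pair in which the exchange was seen. For the measured compounds named here, no measured pair shows the exchange with the methyl group present, and whether the small step carries over remains open. The best guide is still the step of a number 4.8 percentage points lower from compound 1 to compound 2 (within the scatter), so a modest drop is expected, and no step beyond the scatter.

The expected step is a number 5.6 percentage points lower from compound 3 to compound 4 (within the scatter).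

For compound 4 the estimated value is 47%, with an expected range from 30% to 63%.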

Compound 4, oral bioavailability: 25.3%
Beside the measured number, compound 4's estimate is 21.7 percentage points above it; the whole stated range lies above it.
By their numbers in this assay, from the lowest: compounds 2, 1 and 4 (each within the scatter of the next, the first and the last beyond it); then compound 3.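

In this assay, the exchange of 4-chlorophenyl for 3,4-difluorophenyl on an amine nitrogen in a ring proves far from neutral once the methyl group is present, with a number 27.3 percentage points lower from compound 3 to compound 4 (beyond the scatter), so the size of this step depends on the core that carries it: the same change on two cores in this assay, a number 4.8 percentage points lower (within the scatter) from compound 1 to compound 2 and a number 27.3 percentage points lower (beyond the scatter) from compound 3 to compound 4, 22.5 percentage points apart, beyond the scatter of two such steps Seen from the other side, the methyl group still gives a gain with 3,4-difluorophenyl in place, with a number 12.3 percentage points higher from compound 2 to compound 4 (beyond the scatter), but that gain is smaller than the one seen with 4-chlorophenyl: the same change on two cores in this assay, a number 34.8 percentage points higher (beyond the scatter) from compound 1 to compound 3 and a number 12.3 percentage points higher (beyond the scatter) from compound 2 to compound 4, 22.5 percentage points apart, beyond the scatter of two such steps The two changes therefore do not add up across these four compounds, and the high oral bioavailability of compound 3 belongs to the combination of the methyl group with 4-chlorophenyl rather than to the methyl group alone.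

Going by these compounds, whether this dependence holds for other groups on the same ring nitrogen, such as 4-methoxyphenyl, or for an ethyl group in place of the methyl group, remains open. These numbers give oral bioavailability alone, so they do not tell which process in the animal lies behind the gap between the two cores.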